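Terphenyl benzimidazoles: hydroxy for trifluoromethoxy on the methylated core

The source may report more compounds than this note shows. Statements on the series, on what has been measured and on what is new or still open speak of the compounds shown alone.

The series is measured in a functional assay on PC-3 cells (Homo sapiens) for inhibition, read by sulforhodamine B assay; on this read-out higher numbers stand for weaker inhibition of growth and lower numbers for stronger inhibition of growth. Compound 1 `FC(F)(F)Oc1ccc(-c2ccc(-c3ccc(-c4nc5ccccc5[nH]4)cc3)cc2)cc1` gives 100000 nM. Compound 2 `Oc1ccc(-c2ccc(-c3ccc(-c4nc5ccccc5[nH]4)cc3)cc2)cc1` gives 47000 nM. Compound 3 `Cc1ccc2[nH]c(-c3ccc(-c4ccc(-c5ccc(OC(F)(F)F)cc5)cc4)cc3)nc2c1` gives 2010 nM, the lowest of the three numbers. Compound 4 `Cc1ccc2[nH]c(-c3ccc(-c4ccc(-c5ccc(O)cc5)cc4)cc3)nc2c1` is not yet measured.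

The step from compound 1 to compound 2 is hydrogen in place of trifluoromethyl on an oxygen on an aromatic ring; it gave a 2.1-fold lower number from compound 1 to compound 2 (0.33 log units; beyond the scatter). The step from compound 1 to compound 3 is methyl in place of hydrogen on an aromatic carbon; it gave a 50-fold lower number from compound 1 to compound 3 (1.70 log units; beyond the scatter), and this is how the core of compound 3 differs from the core of compound 1. Compound 4 is related to compound 3 as compound 2 is to compound 1: the change is hydrogen in place of trifluoromethyl on an oxygen on an aromatic ring, and its place reads the same word for word as in the earlier pair, so it is the same change, made here on the methylated core instead of the unsubstituted one. Among the compounds with values here, only this one earlier instance is in hand, so nothing is known about whether the change behaves alike on the two cores.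

The expectation rests on that one measured pair: starting from compound 3 at 2010 nM, a step of about the size seen from compound 1 to compound 2, a 2.1-fold lower number from compound 1 to compound 2 (0.33 log units; beyond the scatter), is expected, so a 2.0-fold lower number from compound 3 to compound 4 (0.30 log units; within the scatter) is estimated. Compound 4 is therefore expected to give about 1000 nM in this assay, estimated between 400 nM and 2500 nM.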

Compound 4, concentration for 50% growth inhibition: 30000 nM
The estimate for compound 4 lay 30-fold (1.48 log units) below the measured number; the whole stated range lies below it.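

On the methylated core, hydroxy for trifluoromethoxy gives a 15-fold higher number from compound 3 to compound 4 (1.17 log units; beyond the scatter) in this assay; the change therefore does not carry over from the unsubstituted core, where the step ran the opposite way: the same change on two cores in this assay, a 2.1-fold lower number (0.33 log units; beyond the scatter) from compound 1 to compound 2 and a 15-fold higher number (1.17 log units; beyond the scatter) from compound 3 to compound 4, 32-fold (1.50 log units) apart, beyond the scatter of two such steps. Read from the other side, methyl in place of hydrogen gives a 1.6-fold lower number from compound 2 to compound 4 (0.19 log units; within the scatter) when hydroxy is present, whereas it gave a large step when trifluoromethoxy was present: the same change on two cores in this assay, a 50-fold lower number (1.70 log units; beyond the scatter) from compound 1 to compound 3 and a 1.6-fold lower number (0.19 log units; within the scatter) from compound 2 to compound 4, 32-fold (1.50 log units) apart, beyond the scatter of two such steps. These four compounds show that, in this series, the size of either step depends on what stands at the other place, so a step measured on one core is a poor guide to the same step on the other; they do not show why the two places interact, and a single set of four compounds in one assay does not show whether this holds for other groups or cores.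

Left open is whether the large methyl step requires trifluoromethyl on the oxygen specifically, which a methyl or ethyl group on that oxygen would help to settle on both cores. Also open, going by these compounds, is whether an amine or a carboxylic acid in place of trifluoromethoxy would behave like hydroxy, and whether an ethyl group or chlorine in place of the core methyl would behave like methyl.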